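A few compounds are considered here, and "the series" means these few. Any claim that something is new, unique, unknown or untested is made for them only; others in the source may bear on it.

In an ADME assay on L6 cells (Rattus norvegicus) for cytotoxicity, with a stated time of 72 h (on this read-out lower numbers stand for stronger inhibition and higher numbers for weaker inhibition), three compounds sharing one core have been measured: compound 1 (`CCN(CC)CC(=O)OC1CC2(N3CCCCC3)CC(c3ccccc3)C1C(c1ccccc1)C2`) gives 23900 nM, compound 2 (`CC(C)(C)C(=O)OC1CC2(N3CCCCC3)CC(c3ccccc3)C1C(c1ccccc1)C2`) gives 12000 nM, and compound 3 (`O=C(CN1CCCCC1)OC1CC2(N3CCCCC3)CC(c3ccccc3)C1C(c1ccccc1)C2`) gives 60400 nM. Compound 3 therefore has the highest number of the three and is the weakest inhibitor among them. Compound 4 (`OC1CC2(N3CCCCC3)CC(c3ccccc3)C1C(c1ccccc1)C2`) differs from compound 3 by hydrogen in place of ((piperidin-1-yl)methyl)carbonyl on an oxygen on a saturated carbon. In words, this is hydrogen in place of ((piperidin-1-yl)methyl)carbonyl on an oxygen on a saturated carbon, so that a hydroxy stands where the (((piperidin-1-yl)methyl)carbonyl)oxy stood.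

The measured steps bear on this change only indirectly, as each swaps the group on the carbonyl or its chain and none removes it. They are a 2.0-fold lower number from compound 1 to compound 2 (0.30 log units; within the scatter), a 2.5-fold higher number from compound 1 to compound 3 (0.40 log units; beyond the scatter) and a 5.0-fold higher number from compound 2 to compound 3 (0.70 log units; beyond the scatter). For the measured compounds named here, exchanging that group has so far moved the number only modestly, and no measured compound carries the free hydroxy, so the estimate stays wide. The expected change is a 1.7-fold lower number from compound 3 to compound 4 (0.24 log units; within the scatter), which would stay within the scatter, if anything leaning toward a lower number. For compound 4 the estimated value is 35000 nM, with an expected range from 12000 nM to 100000 nM.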

Compound 4, half-maximal inhibitory concentration: 37300 nM
The estimate for compound 4 lay 1.1-fold (0.03 log units) below the measured number, and the stated range covers the measured number.
By their numbers in this assay, from the lowest: compounds 2, 1, 4 and 3 (each within the scatter of the next, the first and the last beyond it).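

In this assay, taking the whole acyl group off the oxygen and leaving a hydroxy gives a 1.6-fold lower number from compound 3 to compound 4 (0.21 log units; within the scatter) and a 1.6-fold higher number from compound 1 to compound 4 (0.19 log units; within the scatter), so compound 4 cannot be told apart from either compound carrying a basic-free reading of its chain, the ((piperidin-1-yl)methyl)carbonyl of compound 3 or the ((diethylamino)methyl)carbonyl of compound 1. For the compounds shown here, only the (tert-butyl)carbonyl of compound 2 stands apart from the hydroxy, with a 3.1-fold higher number from compound 2 to compound 4 (0.49 log units; beyond the scatter), which makes it the one group of the three for which removal shows a step beyond the scatter. The numbers of compound 1 and compound 3 therefore do not depend on an acyl group being present at this oxygen, while the number of compound 2 does differ from that of the free hydroxy.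

Still open, from the compounds shown here alone, is how this position responds to other groups on the same oxygen, such as a simple acetyl, a benzoyl, a methyl ether or a longer chain ending in a carboxylic acid, and whether any of them goes lower than the (tert-butyl)carbonyl. Nothing at hand offers a reason for these steps.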